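The compounds below may be only part of what the source reports. "The series", "measured", "known", "first", "only" and "open" are said of these compounds alone.

Measured compounds in this series:
compound 1 `COc1ccc(/C=C\C(=O)O)c(OCc2cn(-c3ccc(NC(=O)c4ccccc4)cc3)nn2)c1CC=C(C)C` — 42700 nM
compound 2 `COc1cccc(-n2cc(COc3c(/C=C\C(=O)O)ccc(OC)c3CC=C(C)C)nn2)c1` — 42700 nM
compound 3 `COc1ccc(/C=C\C(=O)O)c(OCc2cn(-c3ccccc3)nn2)c1CC=C(C)C` — 40500 nM

In a functional assay on A549 cells (Homo sapiens) for cytotoxicity, read by MTT assay, with a stated time of 24 h (on this read-out higher numbers stand for weaker inhibition and lower numbers for stronger inhibition), compound 3 sits at the low end of the three numbers, but the steps of a 1.1-fold lower number from compound 1 to compound 3 (0.02 log units; within the scatter) and a 1.1-fold lower number from compound 2 to compound 3 (0.02 log units; within the scatter) are both within the scatter, so the three compounds are not separable on these data.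

Compound 4 `COc1ccc(/C=C\C(=O)O)c(OCc2cn(-c3ccc(C#N)cc3)nn2)c1CC=C(C)C` differs from compound 3 by cyano in place of hydrogen on an aromatic carbon. Both measured steps bear on this change, since each exchanges a substituent on the phenyl for hydrogen, and both were flat. The step from compound 3 to compound 4 is therefore expected to stay within the scatter: a 1.0-fold lower number from compound 3 to compound 4 (0.01 log units; within the scatter). Compound 4 is expected to give 40000 nM in this assay, with a range from 20000 nM to 80000 nM.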

Compound 4, half-maximal inhibitory concentration: 42200 nM
The estimate for compound 4 lay 1.1-fold (0.02 log units) below the measured number; the measured number falls inside the stated range.
By their numbers in this assay, from the lowest: compounds 3, 4, 1 and 2 (each within the scatter of the next).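

Cyano on the aromatic carbon para to a large group leaves the number in this assay within the scatter of the unsubstituted phenyl (a 1.0-fold higher number from compound 3 to compound 4 (0.02 log units; within the scatter)). 4-Cyanophenyl also stays within the scatter of 3-methoxyphenyl (a 1.0-fold lower number from compound 2 to compound 4 (0.01 log units; within the scatter)), and cyano within the scatter of benzamido (a 1.0-fold lower number from compound 1 to compound 4 (0.01 log units; within the scatter)). A nitrile at this place thus joins hydrogen and benzamido with no separation among them, adding a group with a triple bond to that flat set.

From the compounds shown here alone, whether an amine or a carboxylic acid at this place would separate from compound 3 remains open. Nothing available accounts for the flat read-out.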